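The source may hold more compounds than are shown below. What is called first, only, known or untested is meant among the compounds shown, and "the series" means these compounds.

Measured so far, in a physicochemical assay, read by spectrophotometry, with a stated time of 30 min; on this read-out higher numbers stand for an effect only at larger amounts of compound and lower numbers for an effect already at smaller amounts:

Compound 1 `O=C1c2c(O)cc(O)cc2O[C@H](c2cccc(O)c2)[C@H]1O`: compound 1 gives > 100000 nM, which is a limit of the assay.
Compound 2 `O=C1c2c(O)cc(O)cc2O[C@@H](c2ccccc2O)[C@@H]1O`: compound 2 gives > 100000 nM, likewise a limit.
Compound 3 `O=C1c2c(O)cc(O)cc2O[C@H](c2cc(O)cc(O)c2)[C@H]1O`: compound 3 gives > 100000 nM, again a limit.

The step from compound 1 to compound 3 is hydroxy in place of hydrogen on an aromatic carbon, and in this assay it reads as a step that the two limits leave unreadable from compound 1 to compound 3; the reason is the limit of > 100000 nM in this assay, at which 3 of the 3 values shown sit. The difference between the cores of compound 1 and compound 2 is not broken down here. Compound 4 `O=C1c2c(O)cc(O)cc2O[C@@H](c2cccc(O)c2O)[C@@H]1O` is still to be measured; it differs from compound 2 by hydroxy in place of hydrogen on an aromatic carbon, the same kind of change, though here the entering hydroxy sits ortho to a hydroxy group rather than meta to one. Because compound 2 sits at > 100000 nM, compound 4 is expected to stay near that limit, the step that the limit leaves unreadable from compound 2 to compound 4 being only an estimate, with an estimated value of 200000 nM.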

Compound 4, half-maximal effective concentration: 13500 nM
Compound 4: the middle estimate sits 15-fold (1.17 log units) above what was measured; the whole stated range lies above it.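

In this assay, hydroxy in place of hydrogen on an aromatic carbon, here ortho to a hydroxy group, gives an at least 7.4-fold lower number from compound 2 to compound 4 (0.86 log units; beyond the scatter). Compound 2 gives > 100000 nM, which is a limit. The same kind of change on the core of compound 1 cannot be read, so this single step does not show that the change carries from one core to another: the limit of > 100000 nM in this assay, at which 3 of the 4 values shown sit.

Still open is whether the lower number needs the entering hydroxy to sit ortho to a hydroxy group, as compound 4 is the only compound shown with a value off the limit. Also open, as far as these compounds go, is what a methoxy group or an amine in that same place would give.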